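The source may report more compounds than this note shows. Statements on the series, on what has been measured and on what is new or still open speak of the compounds shown alone.

Compound 1 `Nc1cc(N)c2nc(-c3ccccc3)c(Oc3ccc(Cl)c(Cl)c3)nc2c1` carries a 3,4-dichlorophenoxy group on its shared core, and in a functional assay on KM12 cells (Homo sapiens) for inhibition, read by sulforhodamine B assay, with a stated time of 48 h (a higher number here means a weaker inhibitor of growth, a lower number a stronger inhibitor of growth), compound 1 gives 39800 nM. Compound 2 `Nc1cc(N)c2nc(-c3ccccc3)c(Sc3ccc(Cl)c(Cl)c3)nc2c1` differs from it in one place, with (3,4-dichlorophenyl)sulfanyl in place of 3,4-dichlorophenoxy on an aromatic carbon. For compound 2 this assay reports only a limit, < 100000 nM. The step that the limit leaves unreadable from compound 1 to compound 2 therefore cannot be sized, owing to the limit of < 100000 nM in this assay, at which 1 of the 2 values shown sits. Compound 3 `Nc1cc(N)c2nc(-c3ccccc3)c(Sc3ccc(F)cc3)nc2c1` alters the group on sulfur: 4-fluorophenyl in place of 3,4-dichlorophenyl on a sulfur. Within the data shown here, no measured step touches this part of the molecule, and the starting point is itself only a limit, so neither a direction nor a size for the change can be drawn from the measurements at hand. Compound 3 is expected to stay a weak inhibitor of growth, with an estimated step that the limit leaves unreadable from compound 2 to compound 3. The estimate for compound 3 is 40000 nM, with a range from 8000 nM to 100000 nM.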

Compound 3, concentration for total growth inhibition: 49000 nM
The estimate for compound 3 lay 1.2-fold (0.09 log units) below the measured number; the range from low to high includes it.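

With a number now available for a sulfur-linked group at this position, putting (4-fluorophenyl)sulfanyl in place of 3,4-dichlorophenoxy on an aromatic carbon gives a 1.2-fold higher number from compound 1 to compound 3 (0.09 log units; within the scatter) in this assay. This one exchange alters both the linking atom and the halogens on the ring, yet the two compounds it joins cannot be told apart in this read-out. Compound 2 has only a limit, < 100000 nM, and the steps into and out of it cannot be read because of that limit: the limit of < 100000 nM in this assay, at which 1 of the 3 values shown sits.

As far as these compounds go, what the linking atom and the halogens each contribute on their own stays open. Also open, from the compounds shown here alone, is whether an amine, a carboxylic acid or a longer chain in place of 4-fluorophenyl on a sulfur would give a stronger inhibitor of growth.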